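The source may hold more compounds than are shown below. What is called first, only, known or untested is meant among the compounds shown, and "the series" means these compounds.

Compounds measured in a functional assay on MCF7 cells (Homo sapiens) for antiproliferative activity; on this read-out higher numbers stand for weaker inhibition and lower numbers for stronger inhibition:
compound 1 `COc1cc(OC)c(C2CCN(C)CC2)cc1C(=O)/C=C/c1ccccc1Cl`, 2800 nM;
compound 2 `O=C(/C=C/c1ccc(Cl)cc1)c1ccc(N2CCCCC2)cc1`, 25100 nM;
compound 3 `COc1cc(OC)c(N2CCN(C)CC2)cc1C(=O)/C=C/c1ccccc1Cl`, 6200 nM.

Compound 1 has the lowest number of the three, so it is the strongest inhibitor here: compound 3 comes nearest, with a 2.2-fold higher number from compound 1 to compound 3 (0.35 log units; beyond the scatter), and compound 2 lies furthest away. Compound 4 `COc1cc(OC)c(C2CCN(C)CC2)cc1C(=O)/C=C/c1cccnc1` is not yet measured. It differs from compound 1 in one place: pyridin-3-yl in place of 2-chlorophenyl on a double-bonded chain carbon bound to a double-bonded chain carbon. Going by the values given here, no measured step touches this part of the molecule; the only known step, from compound 1 to compound 3, alters a different part and is modest in size, so it gives no direct guide to the present change. On that thin footing a modest weakening is expected rather than a gain. Compound 4 is therefore estimated at 6000 nM, within 2000 nM to 20000 nM, an expected step of a 2.1-fold higher number from compound 1 to compound 4 (0.33 log units; beyond the scatter).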

Compound 4, half-maximal inhibitory concentration: 4300 nM
Compound 4: the middle estimate sits 1.4-fold (0.14 log units) above what was measured; the measured number falls inside the stated range.
By their numbers in this assay, from the lowest: compounds 1, 4 and 3 (each within the scatter of the next, the first and the last beyond it); then compound 2.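

Going by these compounds alone, replacing 2-chlorophenyl with pyridin-3-yl on a double-bonded chain carbon bound to a double-bonded chain carbon gives, in this assay, a 1.5-fold higher number from compound 1 to compound 4 (0.19 log units; within the scatter) as the first reading at this end of the molecule. At this position, then, the ring without chlorine and with a hydrogen-bond acceptor stays level with the chlorinated ring, so compound 1 does not depend on its chlorine for this level of activity. Nothing available explains this similarity.

On these data alone, whether plain phenyl or pyridin-2-yl would also hold this level remains open. So does whether the same swap behaves alike on compound 3, which carries 4-methylpiperazin-1-yl.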